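The source may report more compounds than this note shows. Statements on the series, on what has been measured and on what is new or still open speak of the compounds shown alone.

Working notes on the series.

Among the measured compounds shown here, compound 1, `CCCCCCCCCCCc1cc2cn(COCCO)c(=O)nc2o1`, is the only member with a numerical read-out: in a functional assay on HEL cells (Homo sapiens), read by microscopy (a lower number here means that less compound is tolerated, a higher number that more compound is tolerated), compound 1 gives 80000 nM. Compound 2, `O=c1nc2occc2cn1COCCO`, reaches only a limit of the assay: in this assay compound 2 gives > 400000 nM. Compound 3, `CCCCc1cc2cn(COCCO)c(O)nc-2n1`, likewise reaches only a limit: in this assay compound 3 gives > 400000 nM. For the measured compounds named here, compound 1 thus stands as the one compound for which a minimum cytotoxic concentration has been resolved, while the rest of the series sits at the limit of > 400000 nM in this assay, at which 2 of the 3 values shown sit.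

Compound 4, `CCCCCCCCc1cc2cn(COCCO)c(=O)nc2o1`, has not yet been measured in this assay. It differs from compound 1 as follows: hydrogen in place of propyl on a saturated chain carbon, eight bonds along the chain from an aromatic carbon. Going by the values given here, no pair of measured compounds differing in a single place is available, so the size of this step cannot be read from the series; the expectation rests on compound 1 alone, since compounds 2 and 3 give only limits. The step from compound 1 to compound 4 is expected to be modest, if anything toward more compound tolerated, at a 2.0-fold higher number from compound 1 to compound 4 (0.30 log units; within the scatter). On that basis compound 4 is estimated in this assay at 160000 nM, with a range from 60000 nM to 400000 nM, and a fair chance that only a limit is reported.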

Compound 4, minimum cytotoxic concentration: >= 80000 nM
Compound 4: only a limit was reported (the forecaster's own chance of this, stated with the estimate: 30%); the middle value lies beyond the limit too.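

The change of hydrogen in place of propyl, on a saturated chain carbon, eight bonds along the chain from an aromatic carbon, gives the series its first comparison in a single place: in this assay the result is a number no lower from compound 1 to compound 4 (the limit leaves the size open). Among the compounds shown here, this shows that, at this position, removing propyl did not lower the minimum cytotoxic concentration, a direction that the earlier compounds could not show because no two of them differed in one place only. The reading for compound 4 is a limit and not a number: the limit of >= 80000 nM in this assay, at which 1 of the 4 values shown sits.

From the compounds shown here alone, the size of the step cannot be read, so it remains open whether compound 4 truly differs from compound 1 or lies within the usual scatter of this measurement. Also open is how this assay responds at this position to a longer chain, or to an amine or a carboxylic acid carried on the chain, since the compounds shown contain none of these groups.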